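Swapping a Hydroxymethyl for a Carboxy: an Expected Step

This account rests on a few compounds, and the source may have more. Where it says the series, first, only, none or still open, it means among the compounds named here.

Measured so far:
Compound 2 `O=c1c(OCCO)c(-c2ccc(O)c(O)c2)oc2ccccc12` — 600 nM
Compound 1 `C[N+](C)(C)CCCOc1ccc2c(=O)cc(-c3ccc(O)c(O)c3)oc2c1` — 37300 nM

Both were tested in a functional assay for inhibition, with Rattus norvegicus as the target, using microsomes; on this read-out lower numbers stand for stronger inhibition and higher numbers for weaker inhibition. Compound 2 gives 600 nM, the lowest of the two numbers. Compound 1 gives 37300 nM, a gap beyond the usual scatter, but the two structures differ in several places, so nothing can be read from this pair about any single change.

Compound 3 `O=C(O)COc1c(-c2ccc(O)c(O)c2)oc2ccccc2c1=O` differs from compound 2 in one place only: carboxy in place of hydroxymethyl on a saturated chain carbon bound to an oxygen on an aromatic ring. Among the measured compounds shown here, no step between measured compounds isolates this change, so the expectation rests on compound 2 alone. The expected change is a 2.0-fold higher number from compound 2 to compound 3 (0.30 log units; within the scatter), a modest drift toward a higher number that may not exceed the scatter. Compound 3 is therefore estimated at 1200 nM, with a range from 300 nM to 5000 nM.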

Compound 3, half-maximal inhibitory concentration: 6500 nM
Compound 3: middle estimate off by 5.4-fold (0.73 log units), on the low side, and the stated range ends below it.
By their numbers in this assay, from the lowest: compound 2; then compound 3; then compound 1.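

In this assay, this position turns out to be sensitive to what ends the chain: carboxy in place of hydroxymethyl, on a saturated chain carbon bound to an oxygen on an aromatic ring, gives an 11-fold higher number from compound 2 to compound 3 (1.03 log units; beyond the scatter), a large move toward weaker inhibition. The two groups match in their counts of hydrogen-bond donors and acceptors, and the numbers still part this far, so a small edit at this place is not a neutral one. Nothing available here accounts for the size of this step.

From the compounds shown here alone, whether an amine at the end of this chain, or a longer chain carrying the carboxy, would land nearer compound 2 or compound 3 remains open. Also open, going by these compounds, is whether the same swap would act alike on another core, as compound 1 differs from both compounds in several places.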